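The compounds below may be only part of what the source reports. "The series", "measured", "known", "first", "only" and "open" are said of these compounds alone.

This account follows a small set of compounds examined in a functional assay on cells for positive allosteric modulation of metabotropic glutamate receptor 2 (Homo sapiens), read by scintillation counting and GTPgammaS binding, with a stated time of 30 min; a higher number here means that more compound is needed for the effect, a lower number that less compound is needed. Compound 1 `CC(C)Nc1ccc(-c2ccn3c(CC4CC4)nnc3c2Cl)cc1F` is the starting point: in this assay compound 1 gives 224 nM. Compound 2 `CC(C)Nc1ccc(-c2ccn3c(CC4CC4)nnc3c2C(F)(F)F)cc1F` differs from compound 1 in one place, with trifluoromethyl in place of chloro on an aromatic carbon. In this assay compound 2 gives 93.3 nM, and the step recorded is a 2.4-fold lower number from compound 1 to compound 2 (0.38 log units; beyond the scatter).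

Compound 3 `Clc1cc(-c2ccn3c(CC4CC4)nnc3c2Cl)ccc1NC1CCOCC1` rests on a different core; the difference between the two cores is not broken down here. In this assay compound 3 gives 148 nM, a number that lies within the scatter of both compound 1 and compound 2, so no order among the three can be claimed from it.

Compound 4 `FC(F)(F)c1c(-c2ccc(NC3CCOCC3)c(Cl)c2)ccn2c(CC3CC3)nnc12` has not yet been measured. It differs from compound 3 by trifluoromethyl in place of chloro on an aromatic carbon. The change is the same as that from compound 1 to compound 2, and the surroundings of the place are described in identical words for both pairs, so this is the same change, seen here for the second time.

The expectation for compound 4 rests on a single earlier occurrence: because the same change made a 2.4-fold lower number from compound 1 to compound 2 (0.38 log units; beyond the scatter) in this assay, a step of about a 2.4-fold lower number from compound 3 to compound 4 (0.38 log units; beyond the scatter) is expected from compound 3 to compound 4. Compound 4 is therefore estimated at 62 nM in this assay, with the estimate expected to fall between 30 nM and 130 nM; the wider margin reflects that the core of compound 3 is not that of compound 1.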

Compound 4, half-maximal effective concentration: 18.6 nM
Compound 4: middle estimate off by 3.3-fold (0.52 log units), on the high side; the whole stated range lies above it.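

In this assay, trifluoromethyl in place of chloro on an aromatic carbon gives an 8.0-fold lower number from compound 3 to compound 4 (0.90 log units; beyond the scatter), so the number falls on this core as it did on the core of compound 1. The direction of the change therefore carried over to the second core in these two pairs, but its size did not: the same change on two cores in this assay, a 2.4-fold lower number (0.38 log units; beyond the scatter) from compound 1 to compound 2 and an 8.0-fold lower number (0.90 log units; beyond the scatter) from compound 3 to compound 4, 3.3-fold (0.52 log units) apart, beyond the scatter of two such steps. Within the data shown here, this shows that the size of the step seen on one core was not a safe guide to its size on the other, but with only two pairs it does not show which structural difference goes with the larger step, and it gives no rule for any further core.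

The compounds shown leave open how other groups on the same aromatic carbon, such as a nitrile, a methyl or a bromo group, would compare with chloro and trifluoromethyl on either core. They also leave open whether the gap in step size would persist if the cyclopropylmethyl group gave way to a longer chain or the amine substituent to a different amine.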